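Second methoxy on the aryl ring of compound 1

This account rests on a few compounds, and the source may have more. Where it says the series, first, only, none or still open, it means among the compounds named here.

Measured so far:
compound 1 `COc1ccc(-c2nnc(-c3c[nH]c4ccccc34)o2)cc1` — in a functional assay on DU-145 cells (Homo sapiens) for cytotoxicity, read by MTT assay (on this read-out higher numbers stand for weaker inhibition and lower numbers for stronger inhibition), compound 1 shows > 1000000 nM.
compound 2 `Clc1ccc(-c2nnc(-c3c[nH]c4ccccc34)o2)cc1` — in this assay compound 2 gives 192000 nM.

Compound 1 stands only at a limit of this assay, not at a number (the limit of > 1000000 nM in this assay, at which 1 of the 2 values shown sits). Compound 3 `COc1ccc(-c2nnc(-c3c[nH]c4ccccc34)o2)cc1OC` differs from it by methoxy in place of hydrogen on an aromatic carbon. For the measured compounds named here, the one measured step, an at least 5.2-fold lower number from compound 1 to compound 2 (0.71 log units; beyond the scatter), swaps the methoxy rather than adding a second one, so it bears on this change only loosely. No step beyond the scatter is expected from an added methoxy. Compound 3 is therefore estimated at 1500000 nM, between 300000 nM and 5000000 nM, an expected step that the limit leaves unreadable from compound 1 to compound 3, most probably again reported as a limit.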

Compound 3, half-maximal inhibitory concentration: > 1000000 nM
Compound 3 ended at the assay's limit (the forecaster's own chance of this, stated with the estimate: 70%); the middle value is on the limit's open side.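

No step can be read between compound 1 and compound 3, because both stand at a limit and not at a number: the limit of > 1000000 nM in this assay, at which 2 of the 3 values shown sit. The compounds shown leave open whether methoxy in place of hydrogen changes activity at all, since neither compound has a readable value.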